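Halogen swap on benzyl and phenoxyethyl benzothiazole ethers

This account rests on a few compounds, and the source may have more. Where it says the series, first, only, none or still open, it means among the compounds named here.

Compound 1 `Fc1ccccc1COc1nc2ccccc2s1`, compound 2 `Clc1ccc(OCCOc2nc3ccccc3s2)cc1` and compound 3 `Fc1ccc(OCCOc2nc3ccccc3s2)cc1` have been measured in a functional assay on the whole organism with Mus musculus as the target, in the writhing test, at a dose of 100 mg/kg by the intraperitoneal route; a lower number here means less inhibition, a higher number more inhibition at the dose given (going by the name of the read-out). In this assay compound 1 gives 51.9%, compound 2 gives 68.6% and compound 3 gives 99.9%. The step of a number 31.3 percentage points lower from compound 3 to compound 2 (beyond the scatter) corresponds to chloro in place of fluoro on an aromatic carbon. The difference between the core of compound 1 and the core of compound 3 is not broken down here. Compound 4 `Clc1ccccc1COc1nc2ccccc2s1` is not yet measured; it differs from compound 1 by chloro in place of fluoro on an aromatic carbon, the same kind of change as from compound 3 to compound 2, though here the place is ortho to a large group rather than para to a large group. With a single earlier instance and a different place, a smaller downward step is expected in this assay: a number 18.9 percentage points lower from compound 1 to compound 4 (beyond the scatter). Compound 4 is accordingly estimated at 33%, within a range from 10% to 60%.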

Compound 4, a percentage reported as inhibition, in the whole organism at one dose (the size of the read-out at that dose, not a potency): "not active" (no number reported)
Nothing numeric was reported for compound 4, so the estimate cannot be set against anything.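

Going by these compounds alone, compound 4 is reported as not active without a number, so no step from compound 1 to compound 4 can be read. From the compounds shown here alone, the size of the chloro in place of fluoro change at this place stays open. No evidence bears on this result.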